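Compound 3: estimate after losing the 4-chlorophenyl

The source may hold more compounds than are shown below. What is called first, only, known or untested is meant among the compounds shown, and "the series" means these compounds.

Values in an ADME assay on Vero cells (Chlorocebus sabaeus) for cytotoxicity, read by MTT assay, with a stated time of 96 h; a higher number here means that more compound is tolerated, a lower number that less compound is tolerated:
Compound 1 `C/C(=N\NC(N)=S)c1ccc2c(c1)nc(-c1ccccc1)n2C1CCCCC1`: 20000 nM
Compound 2 `C/C(=N\NC(N)=S)c1ccc2c(c1)nc(-c1ccc(Cl)cc1)n2C1CCCCC1`: > 100000 nM (a limit, not a number)

Compound 2 stands at the limit of > 100000 nM in this assay, at which 1 of the 2 values shown sits, so its true position is not known. Compound 3 `C/C(=N\NC(N)=S)c1ccc2c(c1)nc(-c1ccoc1)n2C1CCCCC1` has furan-3-yl in place of 4-chlorophenyl on an aromatic carbon. Going by the values given here, one measured step bears on this: an at least 5.0-fold higher number from compound 1 to compound 2 (0.69 log units; beyond the scatter), with chloro in place of hydrogen on an aromatic carbon. Compound 3 carries no chloro, and neither does compound 1 at 20000 nM, so a return to a lower number in this assay is expected. Among the compounds with values here, no measured step covers an exchange of the ring itself, which widens the range. The expected step is an at least 3.3-fold lower number from compound 2 to compound 3 (0.52 log units; beyond the scatter). For compound 3 the estimated value is 30000 nM, with an expected range of 8000 nM to 100000 nM.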

Compound 3, half-maximal cytotoxic concentration: 25000 nM
Beside the measured number, compound 3's estimate is 1.2-fold (0.08 log units) above it; low and high end bracket the measured number.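

In this assay, exchanging phenyl for furan-3-yl on the aromatic carbon gives a 1.3-fold higher number from compound 1 to compound 3 (0.10 log units; within the scatter), so this change of aromatic ring, from six-membered to five-membered, shifts the read-out by no more than the scatter. Going by these compounds alone, exchanging 4-chlorophenyl for furan-3-yl gives an at least 4.0-fold lower number from compound 2 to compound 3 (0.60 log units; beyond the scatter), which leaves compound 2, the only chloro compound of the three, apart from compound 1 and compound 3. The full size of that step cannot be read because compound 2 sits at a limit: the limit of > 100000 nM in this assay, at which 1 of the 3 values shown sits.

Still open, as far as these compounds go, is whether the separation of compound 2 is specific to chloro or would also appear with methoxy or an amine on the phenyl ring. Also open, from the compounds shown here alone, is how the read-out responds when this position carries a non-aromatic group, such as a short alkyl chain.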